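Thiophene methyl removal in the anilinopyrimidine series

The source may hold more compounds than are shown below. What is called first, only, known or untested is meant among the compounds shown, and "the series" means these compounds.

Of the compounds shown here, three carry numbers so far. In a functional assay for inhibition, with Homo sapiens as the target (a higher number here means a weaker inhibitor, a lower number a stronger inhibitor), compound 1 `Cc1cccc(Nc2nccc(-c3cccs3)n2)c1` gives 300 nM. Compound 3 `COc1cccc(Nc2nccc(-c3ccc(C)o3)n2)c1` gives 1500 nM in this assay. Compound 2 `Cc1ccc(-c2ccnc(Nc3cccc(N(C)C)c3)n2)s1` gives 5700 nM in this assay, the highest of the three numbers: its gap to compound 3 and its larger gap to compound 1 both lie beyond the scatter. For the measured compounds named here, no pair among the measured compounds differs in one place only, so no single step can be read off directly.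

Compound 4 `CN(C)c1cccc(Nc2nccc(-c3cccs3)n2)c1` is the next one to be measured. Compared with compound 2 it changes in one place: hydrogen in place of methyl on an aromatic carbon. The group that goes sits on the aromatic carbon next to the ring sulfur, two ring bonds from the ring atom that bears a large group.

The expectation is a drop in the number, since compound 1, which also carries an unsubstituted thiophen-2-yl, gives 300 nM, although compound 1 differs from compound 4 elsewhere as well. The step from compound 2 to compound 4 is expected to be a 3.8-fold lower number from compound 2 to compound 4 (0.58 log units; beyond the scatter). For compound 4 the estimate in this assay is 1500 nM, with a range from 400 nM to 5000 nM.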

Compound 4, half-maximal inhibitory concentration: 2400 nM
Compound 4: the middle estimate sits 1.6-fold (0.20 log units) below what was measured, within the range that was stated.
By their numbers in this assay, from the lowest: compound 1; then compounds 3 and 4 (each within the scatter of the next); then compound 2.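

In this assay, the change from 5-methylthiophen-2-yl to thiophen-2-yl gives a 2.4-fold lower number from compound 2 to compound 4 (0.38 log units; beyond the scatter). For the compounds shown here, this is the first single-place reading at this position: with dimethylamino held constant, hydrogen on the aromatic carbon next to the ring sulfur gives the lower number. With thiophen-2-yl held constant, going from methyl to dimethylamino gives an 8.0-fold higher number from compound 1 to compound 4 (0.90 log units; beyond the scatter), so the series now has a second single-place step, at a different site. Nothing available bears on the origin of either step.

From the compounds shown here alone, whether the methyl-to-hydrogen step keeps its direction and size with methyl in place of dimethylamino remains open. Also open, going by these compounds, is how the position next to the ring sulfur responds to chlorine, ethyl or an amine.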